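Replacing the Phenyl Group on an Amine Nitrogen

This account rests on a few compounds, and the source may have more. Where it says the series, first, only, none or still open, it means among the compounds named here.

Values measured in a functional assay on VCaP cells (Homo sapiens) for antiproliferative activity, read by CCK-8 assay, with a stated time of 6 days (a lower number here means a stronger inhibitor, a higher number a weaker inhibitor), are as follows.
- Compound 1 `C[C@@H](Cn1ccc(-c2ccc(C#N)c(Cl)c2)n1)NC(=O)c1ccccc1F` gives 2190 nM
- Compound 2 `C[C@@H](Cn1ccc(-c2ccc(C#N)c(Cl)c2)n1)Nc1ccccc1` gives > 30000 nM (a limit of the assay)
- Compound 3 `C[C@@H](Cn1ccc(-c2ccc(C#N)c(Cl)c2)n1)Nc1ccc2ccccc2n1` gives 870 nM

From the compounds shown here alone, compound 2 has no number, only the limit > 30000 nM in this assay and so its exact place on the scale remains open. Compound 4 `C[C@@H](Cn1ccc(-c2ccc(C#N)c(Cl)c2)n1)Nc1ncnc2nc[nH]c12` keeps the shared core of compound 2 and changes only the group on the amine nitrogen, with a group of 9 heavy atoms (5 carbon, 4 nitrogen; one five-membered aromatic ring with 2 hetero atoms, one six-membered aromatic ring with 2 hetero atoms) in place of a group of 6 heavy atoms (6 carbon; one six-membered aromatic ring of carbon only), on an amine nitrogen as the counted difference.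

Among the compounds with values here, one measured step bears directly on this nitrogen. It is an at least 13-fold higher number from compound 1 to compound 2 (1.13 log units; beyond the scatter) and it is large, so the group at this place can shift the result well beyond the scatter. Other groups at the same nitrogen give measurable values, since compound 1 stands at 2190 nM and compound 3 stands at 870 nM in this assay as well. Neither carries the group that enters compound 4, so the expectation is loose. A large step towards a lower number is expected, though compound 4 could still stay at the limit of the assay.

The estimated step is an at least 10-fold lower number from compound 2 to compound 4 (1.00 log units; beyond the scatter) on these grounds. For compound 4 the expected value is 3000 nM within an estimated range of 500 nM to 20000 nM in this assay overall.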

Compound 4, half-maximal inhibitory concentration: 640 nM
Compound 4: middle estimate off by 4.7-fold (0.67 log units), on the high side; measured number inside the range.
By their numbers in this assay, from the lowest: compounds 4 and 3 (each within the scatter of the next); then compound 1. At a limit, above all of these: compound 2.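

In this assay the group that enters on the amine nitrogen in compound 4 gives a measurable value in place of the phenyl of compound 2, with an at least 46-fold lower number from compound 2 to compound 4 (1.67 log units; beyond the scatter) and this shows that a group without a carbonyl at this place can reach the low end of the values shown. Set against the (2-fluorophenyl)carbonyl group of compound 1 the same group gives a smaller change, with a 3.4-fold lower number from compound 1 to compound 4 (0.53 log units; beyond the scatter) and this still lies beyond the scatter, so at this nitrogen a carbonyl is not needed for a measurable value, as neither compound 3 nor compound 4 carries one there. Compound 2 remains a limit of the assay and not a number, so the step from it is only a bound: the limit of > 30000 nM in this assay, at which 1 of the 4 values shown sits.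

Compound 3 at 870 nM and compound 4 at 640 nM lie within the scatter of each other, so the compounds shown do not separate these two groups on this nitrogen. From the compounds shown here alone, whether a phenyl carrying an amine or a carboxylic acid would give a measurable value at this place stays open, as does the effect of a longer chain between this nitrogen and the ring.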